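Series notes: methoxy removal from compound 3 to compound 4

The source may report more compounds than this note shows. Statements on the series, on what has been measured and on what is new or still open speak of the compounds shown alone.

Measured so far:
compound 1, `O=C(O)Cc1sc(Nc2ccccc2)nc1-c1ccccc1`, sits at a limit of an in vitro functional assay on HEK285-7 cells for antagonist activity at prostaglandin D2 receptor 2 (Homo sapiens), read by BRET and beta-arrestin recruitment; a lower number here means a smaller maximal response, a higher number a larger maximal response: > 70%
compound 2, `COc1ccc(-c2nc(Nc3ccccc3)sc2CC(=O)O)cc1`, sits at the same limit in this assay: > 70%
compound 3, `COc1ccc(-c2nc(-c3ccc(OC)cc3)c(CC(=O)O)s2)cc1`, sits at that limit too in this assay: > 70%

Each of these values is a limit of the assay, not a number. Compound 3 therefore stands at the limit, and the two further values shown are limits as well (the limit of > 70% in this assay, at which 3 of the 3 values shown sit). The two steps between measured compounds, a step that the two limits leave unreadable from compound 1 to compound 2 and a step that the two limits leave unreadable from compound 2 to compound 3, are both unreadable in size, since both ends sit at the limit.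

Compound 4, `COc1ccc(-c2nc(-c3ccccc3)c(CC(=O)O)s2)cc1`, is unmeasured. It differs from compound 3 by hydrogen in place of methoxy on an aromatic carbon. Going by the values given here, no measured step removes a methoxy from a ring of a compound already at the limit, so neither step bears directly on this change, and both are unreadable anyway. The expectation for compound 4 in this assay is to remain at the limit; the step that the limit leaves unreadable from compound 3 to compound 4 is expected to be none beyond the scatter. Compound 4 is estimated at 82%, ranging from 65% to 100%.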

Compound 4, largest response reached (reported as efficacy), in percent of the reference or control that the assay uses: > 70%
Compound 4: only a limit was reported (the forecaster's own chance of this, stated with the estimate: 80%); the middle value is on the limit's open side.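

No step can be read between compound 3 and compound 4 in this assay, because both values are limits of the assay, not numbers: the limit of > 70% in this assay, at which 4 of the 4 values shown sit.

The compounds shown leave open how far any of these changes shifts the maximal response, since every value shown is a limit.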